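The compounds below may be only part of what the source reports. "The series", "measured", "known", "first", "only" and "open" are said of these compounds alone.

Measured compounds:
- compound 1, `NS(=O)(=O)CC(=O)NCCSc1nonc1/C(=N/O)Nc1cccc(C(F)F)c1`, > 3 h in an ADME assay on microsomes from liver (Homo sapiens) for metabolic stability; a higher number here means that the compound lasts longer, a lower number that the compound disappears faster
- compound 2, `CS(=O)(=O)CC(=O)NCCSc1nonc1/C(=N/O)Nc1ccc(F)c(C(F)F)c1`, 1.27 h in this assay

Two compounds have been run in this assay. For compound 1 the reading of > 3 h is a limit of the assay rather than a number, as stated in the limit of > 3 h in this assay, at which 1 of the 2 values shown sits. Going by the values given here, compound 2 is therefore the only compound with an actual number, 1.27 h. Among the compounds with values here, no step between the two can be counted.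

Compound 3, `CC(C)(O)CC(=O)NCCSc1nonc1/C(=N/O)Nc1ccc(F)c(C(F)F)c1`, has not yet been measured in this assay. It differs from compound 2 in one place: 1-hydroxy-1-methylethyl in place of methylsulfonyl on a saturated chain carbon bound to a carbonyl carbon.

Within the data shown here, no measured pair in this set shows what such a change does in this assay, so the direction of the step is open. The expectation is a step from compound 2 to compound 3 of a 1.0-fold higher number from compound 2 to compound 3 (0.01 log units; within the scatter), that is, no movement beyond the usual scatter. Compound 3 is accordingly estimated at 1.3 h, with a range from 0.6 h to 3 h.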

Compound 3, half-life: 0.937 h
The estimate for compound 3 lay 1.4-fold (0.14 log units) above the measured number; the measured number falls inside the stated range.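

Going by these compounds alone, compound 2 and compound 3 form the only pair in this assay that differ in one place, and putting 1-hydroxy-1-methylethyl in place of methylsulfonyl on a saturated chain carbon bound to a carbonyl carbon gives a 1.4-fold lower number from compound 2 to compound 3 (0.13 log units; within the scatter). The exchange replaces a group with 0 hydrogen-bond donors and 2 hydrogen-bond acceptors by one with 1 hydrogen-bond donor and 1 hydrogen-bond acceptor at the same count of 4 heavy atoms, and in this single pair the half-life stays within the scatter. Compound 1 stands at a limit of the assay, so no step to it can be read: the limit of > 3 h in this assay, at which 1 of the 3 values shown sits.

Going by these compounds, whether the number in this assay would hold with a group of another kind at this place, such as a carboxylic acid, an amine or a longer chain ending in a hydroxyl, remains open. On these data alone, it is also open whether the same exchange would read alike with trifluoromethyl in place of the difluoromethyl group on the shared core.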